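Removing a Fluorine from a Weak Cell-Growth Inhibitor

A few compounds are considered here, and "the series" means these few. Any claim that something is new, unique, unknown or untested is made for them only; others in the source may bear on it.

Measured so far:
- compound 1, `O=C1C=C(Nc2cccc(F)c2)C(=O)c2c1nc1n2[C@H]2OC[C@@H](O)[C@H]2OC1`: 7030 nM
- compound 2, `O=C1C(N2CCCCC2)=CC(=O)c2c1nc1n2[C@H]2OC[C@@H](O)[C@H]2OC1`: > 8000 nM, which is a limit of the assay rather than a number

Both compounds were tested in a functional assay on ECa-109 cells for inhibition, with ECa-109 cell line (Homo sapiens) as the target, read by sulforhodamine B assay; on this read-out lower numbers stand for stronger inhibition and higher numbers for weaker inhibition. Among the measured compounds shown here, compound 1 is the only compound with an actual number; compound 2 reached only a limit. The value of compound 2 is a limit, so nothing more than that can be said of it. For the measured compounds named here, the two compounds differ in more than one place, so no single change connects them, and their values show only that compound 1 gives a number where compound 2 does not.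

The next compound, compound 3, `O=C1C=C(Nc2ccccc2)C(=O)c2c1nc1n2[C@H]2OC[C@@H](O)[C@H]2OC1`, is compound 1 with one change: hydrogen in place of fluoro on an aromatic carbon. Going by the values given here, no measured pair in this set shows what such a change does. With compound 1 at 7030 nM, the step from compound 1 to compound 3 is expected to be small, a 1.2-fold higher number from compound 1 to compound 3 (0.08 log units; within the scatter), not clearly beyond the usual scatter, if anything a slight weakening. Compound 3 is therefore expected to give about 8500 nM, within a range from 4000 nM to 18000 nM.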

Compound 3, half-maximal inhibitory concentration: 4970 nM
Compound 3: the middle estimate sits 1.7-fold (0.23 log units) above what was measured, within the range that was stated.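

Among the compounds shown here, replacing 3-fluorophenyl with phenyl gives the first direct reading of this change in this assay: a 1.4-fold lower number from compound 1 to compound 3 (0.15 log units; within the scatter). The fluoro group on this aromatic carbon can therefore be exchanged for hydrogen without a shift that stands out from repeat measurements, and compound 1 and compound 3 count as equal on this read-out. Compound 2 remains at a limit of the assay, which is not a number: the limit of > 8000 nM in this assay, at which 1 of the 3 values shown sits.

The compounds shown compare only fluoro and hydrogen at this place, leaving open whether another group there, such as a methoxy group, a chlorine atom or a carboxylic acid, would move the number beyond the scatter. Also open, on these data alone, is whether the same exchange would read the same way on another carbon of the ring or on a different core, as a single pair cannot establish a pattern.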